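This account rests on a few compounds, and the source may have more. Where it says the series, first, only, none or still open, it means among the compounds named here.

Measured in a functional assay on SGC-7901 cells (Homo sapiens) for antiproliferative activity, read by MTT assay, with a stated time of 72 h; a lower number here means a stronger inhibitor, a higher number a weaker inhibitor:
Compound 1 `CCOC(=O)c1cc(-c2cc(OC)c(OC)c(OC)c2)c(-c2cccc(Br)c2)s1`: > 100000 nM (a limit)
Compound 2 `CCOC(=O)c1cc(-c2cc(OC)c(OC)c(OC)c2)c(-c2ccc(OC)c(OCc3ccccc3)c2)s1`: > 100000 nM (a limit)
Compound 3 `COc1cc(-c2cc(C(=O)O)sc2-c2cccc(Br)c2)cc(OC)c1OC`: 93400 nM

Going by the values given here, compound 3 is the only one with a number, 93400 nM. The rest of the evidence is the limit of > 100000 nM in this assay, at which 2 of the 3 values shown sit. Compound 4 `COc1ccc(-c2sc(C(=O)O)cc2-c2cc(OC)c(OC)c(OC)c2)cc1O` changes the aryl group of compound 3: 3-hydroxy-4-methoxyphenyl in place of 3-bromophenyl on an aromatic carbon. Among the compounds with values here, the one measured step, an at least 1.0-fold lower number from compound 1 to compound 3 (0.02 log units; that floor lies within the scatter), concerns the ester instead and gives no size for this exchange. With compound 3 at 93400 nM, this assay leaves room mainly for a lower number, so a moderate drop is expected, on thin evidence. The expected step is a 3.1-fold lower number from compound 3 to compound 4 (0.49 log units; beyond the scatter). For compound 4 the estimated value is 30000 nM, with an expected range of 4000 nM to 100000 nM.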

Compound 4, half-maximal inhibitory concentration: 6100 nM
Beside the measured number, compound 4's estimate is 4.9-fold (0.69 log units) above it; the measured number falls inside the stated range.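

In this assay, the aryl group on the aromatic carbon next to the ring sulfur proves able to shift the read-out strongly: a 15-fold lower number from compound 3 to compound 4 (1.19 log units; beyond the scatter). The earlier compounds shown here gave no size for any exchange at this position, and most of what they offered was a ceiling: the limit of > 100000 nM in this assay, at which 2 of the 4 values shown sit.

Which part of the entering group carries the step stays open, since the hydroxy and methoxy groups arrive together as the bromine leaves. As far as these compounds go, how an amine in place of the hydroxy, or the ethyl ester of compound 4, would read is also open.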